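A few compounds are considered here, and "the series" means these few. Any claim that something is new, unique, unknown or untested is made for them only; others in the source may bear on it.

Working notes on the series. The shared core carries a benzylamine arm, and the arm alone varies. In a functional assay on G-361 cells (Homo sapiens) for antiproliferative activity, with a stated time of 72 h (a higher number here means a weaker inhibitor, a lower number a stronger inhibitor), compound 1 `OC[C@H]1O[C@@H](n2cnc3c(NCc4cccc(Br)c4)ncnc32)[C@H](O)[C@@H]1O` gives > 166000 nM, which is a limit of the assay and not a number. Compound 3 `OC[C@H]1O[C@@H](n2cnc3c(NCc4c(F)ccc(F)c4F)ncnc32)[C@H](O)[C@@H]1O` likewise gives > 166000 nM in this assay, again a limit. For compound 2 `COc1cccc(CNc2ncnc3c2ncn3[C@@H]2O[C@H](CO)[C@@H](O)[C@H]2O)c1OC` the outcome in this assay is "not determined" (no result reported). Going by the values given here, the only one-point step, a step that the two limits leave unreadable from compound 1 to compound 3, therefore cannot be read, since the limit of > 166000 nM in this assay, at which 2 of the 3 values shown sit, holds both ends. Compound 4 `OC[C@H]1O[C@@H](n2cnc3c(NCc4ccc(F)c(Cl)c4)ncnc32)[C@H](O)[C@@H]1O` is the next arm: 3-chloro-4-fluorophenyl in place of 3-bromophenyl on a saturated chain carbon bound to a nitrogen on an aromatic ring. Among the compounds with values here, no measured step bears on this change, so no direction beyond the scatter is expected; compound 4 is expected to sit at 200000 nM (range 50000 nM to 800000 nM), a step that the limit leaves unreadable from compound 1 to compound 4 that is itself only an estimate.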

Compound 4, half-maximal inhibitory concentration: > 166000 nM
Compound 4 gave a limit, no number; the forecaster's own chance of this, stated with the estimate: 80%; the middle value is on the limit's open side.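

Compound 4 gives only a limit, so neither its step from compound 1 nor its step from compound 3 can be read: the limit of > 166000 nM in this assay, at which 3 of the 4 values shown sit.

The compounds shown leave open whether any arm on the shared core gives a true number in this assay.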